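The source may report more compounds than this note shows. Statements on the series, on what has been measured and on what is new or still open speak of the compounds shown alone.

Compound 1 `Nc1cc(N)c2nc(-c3ccccc3)c(Oc3ccc(Cl)c(Cl)c3)nc2c1` was tested in a functional assay on K562 cells (Homo sapiens) for inhibition, read by sulforhodamine B assay, with a stated time of 48 h; on this read-out lower numbers stand for higher toxicity in this test and higher numbers for lower toxicity in this test. In this assay compound 1 gives only a limit, < 100000 nM. Compound 2 `CCOC(=O)[C@H](CCC(=O)O)NC(=O)c1ccc(CNc2nc3cc(N)cc(N)c3nc2-c2ccccc2)cc1` gives in this assay also only a limit, < 100000 nM. Compound 3 `COc1cc(CNc2nc3cc(N)cc(N)c3nc2-c2ccccc2)cc(OC)c1OC` gives in this assay a limit as well, < 50200 nM. Compound 1 thus sits at the limit of < 100000 nM in this assay, at which 2 of the 3 values shown sit. Compound 3 sits at the limit of < 50200 nM in this assay, at which 1 of the 3 values shown sits. Among the measured compounds shown here, no step between two measured compounds can be read from these three limits.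

Compound 4 `Nc1cc(N)c2nc(-c3ccccc3)c(NCc3ccc(F)cc3)nc2c1` differs from compound 1 in one place: (4-fluorobenzyl)amino in place of 3,4-dichlorophenoxy on an aromatic carbon. With only limits to build on, the change is expected to stay within the scatter, and the estimate for compound 4 in this assay is 30000 nM, ranging from 5000 nM to 100000 nM. This corresponds to an expected step that the limit leaves unreadable from compound 1 to compound 4, most likely again reported only as a limit.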

Compound 4, concentration lethal to 50% of the cells: < 100000 nM
Compound 4 was reported as a limit; the forecaster's own chance of this, stated with the estimate: 65%; the middle value is on the limit's open side.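

In this assay compound 4 gives < 100000 nM, which is a limit. Among the compounds shown here, compound 1 also gives only a limit, and no step between compound 1 and compound 4 can be read. The compounds shown leave open what actual lethal concentration lies behind each limit.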